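Benzyl ring substituent swapped: fluorine out, ester in

The source may report more compounds than this note shows. Statements on the series, on what has been measured and on what is new or still open speak of the compounds shown alone.

Three compounds sharing one core have numbers in a functional assay on a cell-free system (plasma, Oryctolagus cuniculus) for inhibition, with stated times of 5 min, 1 min and 6 min; on this read-out higher numbers stand for weaker inhibition and lower numbers for stronger inhibition:
Compound 1, `CCOC(=O)c1c(C)nc(-c2cccc(C#N)c2)n1C`, gives 22100 nM.
Compound 2, `CCOC(=O)COn1c(-c2cccc(C#N)c2)nc(C)c1C(=O)OCC`, gives 6800 nM.
Compound 3, `CCOC(=O)c1c(C)nc(-c2cccc(C#N)c2)n1OCc1ccccc1F`, gives 8990 nM.

Compound 3 holds the second highest number of the three: a 2.5-fold lower number from compound 1 to compound 3 (0.39 log units; beyond the scatter), while a 1.3-fold higher number from compound 2 to compound 3 (0.12 log units; within the scatter). Compound 4, `CCOC(=O)c1c(C)nc(-c2cccc(C#N)c2)n1OCc1ccc(C(=O)OC)cc1`, differs from compound 3 by 4-(methoxycarbonyl)phenyl in place of 2-fluorophenyl on a saturated chain carbon bound to an oxygen on an aromatic ring. Within the data shown here, the only measured step at this same place is the one from compound 2 to compound 3, which stayed within the scatter. The steps of a 3.3-fold lower number from compound 1 to compound 2 (0.51 log units; beyond the scatter) and a 2.5-fold lower number from compound 1 to compound 3 (0.39 log units; beyond the scatter) show that both replacements of the methyl on the aromatic nitrogen lowered the number modestly. Compound 4 keeps such a replacement, so no step beyond the scatter is expected: a 1.1-fold lower number from compound 3 to compound 4 (0.05 log units; within the scatter). The estimate for compound 4 in this assay is 8000 nM, with a range from 3500 nM to 18000 nM.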

Compound 4, half-maximal inhibitory concentration: 9470 nM
Compound 4: the middle estimate sits 1.2-fold (0.07 log units) below what was measured; measured number inside the range.
By their numbers in this assay, from the lowest: compounds 2, 3 and 4 (each within the scatter of the next); then compound 1.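

At the saturated chain carbon bound to the oxygen, the larger 4-(methoxycarbonyl)phenyl group, with its two hydrogen-bond acceptors, gives no step beyond the scatter: a 1.1-fold higher number from compound 3 to compound 4 (0.02 log units; within the scatter), and a 1.4-fold higher number from compound 2 to compound 4 (0.14 log units; within the scatter). This place has now held ethoxycarbonyl, 2-fluorophenyl and 4-(methoxycarbonyl)phenyl, and all three compounds lie within the scatter of one another. No available measurement explains this closeness. On these data alone, it remains open whether an amine or a carboxylic acid at this place would give a step beyond the scatter, and the same goes for a longer chain.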